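Dropping the triazole: what compound 4 may do

The compounds below may be only part of what the source reports. "The series", "measured", "known", "first", "only" and "open" are said of these compounds alone.

Measured so far in a functional assay on DU-145 cells (Homo sapiens) for antiproliferative activity, read by MTT assay, with a stated time of 48 h (a lower number here means a stronger inhibitor, a higher number a weaker inhibitor), as follows
- Compound 1 `C/C(=C\CC/C(C)=C/CC[C@@H]1[C@@]2(C)CCC(=O)C(C)(C)[C@H]2CC[C@@]1(C)O)CC/C=C(\C)C(=O)OCc1cn(-c2ccc(F)cc2)nn1` gives > 150000 nM as a limit
- Compound 2 `COc1ccccc1-n1cc(COC(=O)/C(C)=C/CC/C(C)=C/CC/C(C)=C/CC[C@@H]2[C@@]3(C)CCC(=O)C(C)(C)[C@H]3CC[C@@]2(C)O)nn1` gives > 150000 nM as a limit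
- Compound 3 `C/C(=C\CC/C(C)=C/CC[C@@H]1[C@@]2(C)CCC(=O)C(C)(C)[C@H]2CC[C@@]1(C)O)CC/C=C(\C)C(=O)OCc1cn(-c2ccccc2[N+](=O)[O-])nn1` gives > 150000 nM as a limit

None of these results is an exact number, since each is a limit of the assay. Compound 1 stands at > 150000 nM as a limit, not as a measured potency. The whole set looks the same: the record shows the limit of > 150000 nM in this assay, at which 3 of the 3 values shown sit, and nothing more exact.

Compound 4 `C#CCOC(=O)/C(C)=C/CC/C(C)=C/CC/C(C)=C/CC[C@@H]1[C@@]2(C)CCC(=O)C(C)(C)[C@H]2CC[C@@]1(C)O` keeps the shared core and the ester but changes the far end of the molecule. ethynyl in place of 1-(4-fluorophenyl)-1H-1,2,3-triazol-4-yl on a saturated chain carbon bound to an oxygen next to a carbonyl group is the whole difference, ethynyl in place of 1-(4-fluorophenyl)-1H-1,2,3-triazol-4-yl on a saturated chain carbon bound to an oxygen next to a carbonyl group.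

The measured steps only bear on this indirectly, as each swaps a group on the aryl part and keeps the triazole. They are a step that the two limits leave unreadable from compound 1 to compound 2 and a step that the two limits leave unreadable from compound 1 to compound 3 and also a step that the two limits leave unreadable from compound 2 to compound 3 with no size to read. They give no direction for this assay either, so the plain expectation is no clear change. a number no higher from compound 1 to compound 4 (the limit leaves the size open) is the estimated step on that basis. For compound 4 the estimate is 150000 nM with a range from 50000 nM to 400000 nM as its expected spread.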

Compound 4, half-maximal inhibitory concentration: 46100 nM
Compound 4: the middle estimate sits 3.3-fold (0.51 log units) above what was measured, and the stated range ends above it.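

Replacing the 1-(4-fluorophenyl)-1H-1,2,3-triazol-4-yl with ethynyl on the saturated chain carbon bound to an oxygen next to a carbonyl group gives, in this assay, an at least 3.2-fold lower number from compound 1 to compound 4 (0.51 log units; beyond the scatter). The swaps on the aryl ring could not be read, whereas this change at the far end of the molecule can, which makes this position the first one here where a change in structure shows up as a change in the read-out, although the size is only a minimum, as the value for compound 1 is a limit and not a number. Compound 4 is also the only compound shown with an exact value, while the rest stay at the assay's ceiling: the limit of > 150000 nM in this assay, at which 3 of the 4 values shown sit.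

From the compounds shown here alone, it remains open whether the step comes from the ethynyl group itself or simply from the loss of the triazole and its aryl ring, and a triazole carrying no aryl ring would bear on that question. Going by these compounds, what a plain methyl ester, a free carboxylic acid or a longer chain ending in ethynyl would give at this place is also open.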